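The compounds below may be only part of what the source reports. "The series", "measured", "known", "first", "only" and "open" are said of these compounds alone.

In a functional assay on HT-29 cells (Homo sapiens) for cytotoxicity, read by MTT assay, with a stated time of 48 h (a lower number here means a stronger inhibitor, a higher number a weaker inhibitor), compound 1 `OC[C@@H]1C[C@H](CO)[C@@H]2C(c3ccc(Br)cc3)=NO[C@H]12` gives 37.3 ug/mL. Compound 2 `COc1ccc(C2=NO[C@@H]3[C@H](CO)C[C@H](CO)[C@H]23)cc1` gives > 50 ug/mL, which is a limit of the assay and not a number. Compound 3 `COc1ccc(C2=NO[C@@H]3[C@H](CO)C[C@H](CO)[C@H]23)cc1OC` differs from compound 2 by methoxy in place of hydrogen on an aromatic carbon, ortho to a methoxy group. Among the measured compounds shown here, the one measured step that bears on this is an at least 1.3-fold higher number from compound 1 to compound 2 (0.12 log units; that floor lies within the scatter), methoxy in place of bromo. Nothing beyond the scatter is expected in this assay, and the estimated step is a step that the limit leaves unreadable from compound 2 to compound 3. Compound 3 is estimated at 55 ug/mL, with an expected range of 30 ug/mL to 100 ug/mL.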

Compound 3, half-maximal inhibitory concentration: > 50 ug/mL
Compound 3: no number, only a limit; the forecaster's own chance of this, stated with the estimate: 70%; the middle value lies beyond the limit too.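

Among the compounds shown here, no step from compound 2 to compound 3 can be read, because both values are limits of the assay and not numbers: the limit of > 50 ug/mL in this assay, at which 2 of the 3 values shown sit. Going by these compounds, whether methoxy in place of hydrogen on an aromatic carbon changes the read-out at all stays open.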